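Amide-nitrogen substituents in a cell toxicity series

The source may hold more compounds than are shown below. What is called first, only, known or untested is meant among the compounds shown, and "the series" means these compounds.

Compound 1 `COc1ccc2nc(C)cc(OCC(=O)Nc3cccc(C)c3)c2c1`: 39800 nM
Compound 2 `COc1ccc2nc(C)cc(OCC(=O)Nc3cc(F)cc(F)c3)c2c1`: > 100000 nM
Compound 3 `COc1ccc2nc(C)cc(OCC(=O)Nc3ccc(Cl)c(OC)c3)c2c1`: > 100000 nM

Among the measured compounds shown here, in a toxicity assay on HepG2 cells (Homo sapiens) for inhibition, read by CellTiter-Glo, with a stated time of 48 h (on this read-out lower numbers stand for stronger inhibition and higher numbers for weaker inhibition), compound 1 gives 39800 nM, the only full number in the set. For compound 2 the read-out is a limit of the assay, > 100000 nM. For compound 3 the read-out is likewise a limit of the assay, > 100000 nM. Compound 3 thus stands at the weak end of the numbers shown, together with compound 2, at the limit of > 100000 nM in this assay, at which 2 of the 3 values shown sit. For the measured compounds named here, the two readable steps both run from the single measured number into that limit: an at least 2.5-fold higher number from compound 1 to compound 2 (0.40 log units; beyond the scatter) and an at least 2.5-fold higher number from compound 1 to compound 3 (0.40 log units; beyond the scatter). The remaining step, a step that the two limits leave unreadable from compound 2 to compound 3, cannot be sized.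

Compound 4 `COc1ccc2nc(C)cc(OCC(=O)NC3CONC3=O)c2c1` differs from compound 3 in one place: a group of 6 heavy atoms (3 carbon, 1 nitrogen, 2 oxygen; one five-membered non-aromatic ring with 2 hetero atoms) in place of a group of 9 heavy atoms (7 carbon, 1 oxygen, 1 chlorine; one six-membered aromatic ring of carbon only), on an amide-type nitrogen. Going by the values given here, the steps that bear on this change are the two known ones, each at least modest and each ending at the limit; no step starting from compound 3 has a readable size. Since compound 3 itself sits only at the limit, the expected step of a number no higher from compound 3 to compound 4 (the limit leaves the size open) is taken as none beyond the scatter. Compound 4 is therefore expected at 100000 nM, within 30000 nM to 300000 nM, and most likely reported again as a limit rather than a number.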

Compound 4, half-maximal inhibitory concentration: > 100000 nM
Compound 4 was reported as a limit; the forecaster's own chance of this, stated with the estimate: 70%; the middle value lies on the limit itself.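

Compound 4 adds a different kind of group to this position on the amide-type nitrogen: its five-membered non-aromatic ring with 2 hetero atoms replaces the six-membered aromatic rings of carbon only carried by compounds 1 to 3. In this assay compound 4 gives > 100000 nM, which is a limit of the assay and not a number. The only readable new step, an at least 2.5-fold higher number from compound 1 to compound 4 (0.40 log units; beyond the scatter), shows that a non-aromatic ring at this position also leaves the one full number behind, and the steps among compounds 2, 3 and 4 cannot be read, so the three groups cannot be ranked against one another and the series now rests largely on a single measured value: the limit of > 100000 nM in this assay, at which 3 of the 4 values shown sit.

The compounds shown leave open how far compounds 2, 3 and 4 lie from one another and whether any of them would give a full number in this assay. They also leave open whether a group without a ring on the amide-type nitrogen, such as a longer alkyl chain or one ending in an amine or a carboxylic acid, would give a full number there.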